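Nitro sulfone benzamides: amide cap variation

The source may hold more compounds than are shown below. What is called first, only, known or untested is meant among the compounds shown, and "the series" means these compounds.

Measured so far:
compound 1, `CC(C)N(C(=O)CCNC(=O)c1ccc(S(C)(=O)=O)c([N+](=O)[O-])c1)C(C)C`: > 60000 nM, a limit of the assay
compound 2, `CN(Cc1cccc(F)c1)C(=O)CCCNC(=O)c1ccc(S(C)(=O)=O)c([N+](=O)[O-])c1`: > 60000 nM, a limit of the assay
compound 3, `CS(=O)(=O)c1ccc(C(=O)NCC(=O)N2CCCCC2)cc1[N+](=O)[O-]`: 44000 nM

In an assay on isolated protein for inhibition of thyroid hormone receptor alpha (Homo sapiens), read by fluorescence polarization (a higher number here means a weaker inhibitor, a lower number a stronger inhibitor), compound 1 gives > 60000 nM, which is a limit of the assay and not a number. Compound 2 also gives only > 60000 nM, a limit. Within the data shown here, compound 3 is the one compound of the three with a number, 44000 nM. Compound 1 therefore stands at the limit of > 60000 nM in this assay, at which 2 of the 3 values shown sit, and nothing in the shown data separates it from compound 2; compound 3 lies close to that limit as well.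

Compound 4, `CS(=O)(=O)c1ccc(C(=O)NCCC(=O)N2CCCc3ccccc32)cc1[N+](=O)[O-]`, has not been measured in this assay. It differs from compound 1 in one place: 1,2,3,4-tetrahydroquinolin-1-yl in place of diisopropylamino on a carbonyl carbon. Among the measured compounds shown here, no measured pair shares this change, so the expectation rests on the three values shown, all of which sit at or near the limit. The step of an at least 1.2-fold lower number from compound 1 to compound 4 (0.07 log units; that floor lies within the scatter) is expected to be none beyond the scatter. Compound 4 is expected to give about 50000 nM in this assay, with a range from 15000 nM to 200000 nM, and a limit rather than a number is thought at least as likely.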

Compound 4, half-maximal inhibitory concentration: > 60000 nM
Compound 4: a limit, no number; the forecaster's own chance of this, stated with the estimate: 55%; at least 1.2-fold (0.07 log units) between middle value and limit.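

In this assay, compound 4 gives only a limit, as compound 1 does, so no step can be read between compound 1 and compound 4. The compounds shown leave open whether any amide cap moves this series clear of the limit: the limit of > 60000 nM in this assay, at which 3 of the 4 values shown sit.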